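Swapping the sulfur substituent of a weak growth inhibitor

A few compounds are considered here, and "the series" means these few. Any claim that something is new, unique, unknown or untested is made for them only; others in the source may bear on it.

Compound 1, with structure `Cc1ccc(S/C(=C/c2sccc2C)C(=O)c2ccc(Br)cc2)cc1`, was tested in a functional assay on DU-145 cells (Homo sapiens) for inhibition, read by trypan blue exclusion, with a stated time of 96 h (a lower number here means a stronger inhibitor of growth, a higher number a weaker inhibitor of growth), where compound 1 gives 50000 nM. Compound 2, `Cc1ccc(S/C(=C/c2ccc(F)c(C)c2)C(=O)c2ccc(Br)cc2)cc1`, gives 25000 nM in the same assay, and compound 3, `COc1ccc(/C=C(/Sc2ccc(C)cc2)C(=O)c2ccc(Br)cc2)cc1`, gives 50000 nM. Compound 1 stands level with compound 3 at the top of these three numbers, and the step of a 2.0-fold lower number from compound 1 to compound 2 (0.30 log units; within the scatter) lies within the scatter, as do no change at the digits printed from compound 1 to compound 3 (within the scatter) and a 2.0-fold higher number from compound 2 to compound 3 (0.30 log units; within the scatter). None of the three compounds can be called stronger or weaker than another.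

Compound 4, `Cc1ccsc1/C=C(/SCc1ccc(F)cc1)C(=O)c1ccc(Br)cc1`, differs from compound 1 in one place: 4-fluorobenzyl in place of 4-methylphenyl on a sulfur. Going by the values given here, the three measured steps all change the aryl group on the double-bonded chain carbon and leave the group on sulfur untouched, so no measured step speaks to this change. With nothing in the data pointing either way, no step beyond the scatter is expected. Compound 4 is therefore expected to come out near compound 1, at an estimated 50000 nM, within a range of 20000 nM to 120000 nM, an expected step of no change at the digits printed from compound 1 to compound 4 (within the scatter).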

Compound 4, concentration for 50% growth inhibition: 50000 nM
Beside the measured number, compound 4's estimate shows no gap at the digits printed, within the range that was stated.
By their numbers in this assay, from the lowest: compounds 2, 1, 3 and 4 (each within the scatter of the next).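

Going by these compounds alone, the earlier compounds changed only the aryl group on the double-bonded chain carbon, so compound 4 gives the first reading of a change on the sulfur. In this assay the exchange of 4-methylphenyl for 4-fluorobenzyl gives no change at the digits printed from compound 1 to compound 4 (within the scatter) and so shows no measurable effect on growth inhibition for this one swap on the sulfur. No supporting measurement is available to explain this result.

On these data alone, whether a different kind of group on the sulfur, such as a chain ending in an amine or a carboxylic acid, would shift the number beyond the scatter remains open. As far as these compounds go, it is also open whether plain benzyl would read the same as 4-fluorobenzyl, and whether this swap would hold with the other aryl groups on the chain carbon.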